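Thiourea series: replacing the butylcyclohexyl group with fluoro

This account rests on a few compounds, and the source may have more. Where it says the series, first, only, none or still open, it means among the compounds named here.

Of the compounds shown here, two have been measured in an ADME assay on BHK cells (Mesocricetus auratus) for cytotoxicity, read by MTT assay, with a stated time of 96 h; a lower number here means that less compound is tolerated, a higher number that more compound is tolerated. Compound 1 `CC[C@H]1CC[C@H](c2ccc(NC(=S)Nc3cccc(C(F)(F)F)c3)cc2)CC1` gives 10000 nM. Compound 2 `CCCC[C@H]1CC[C@H](c2ccc(NC(=S)Nc3cccc(C(F)(F)F)c3)cc2)CC1` gives 9500 nM, the lowest of the two numbers, with compound 1 as its nearest neighbour; the step of a 1.1-fold lower number from compound 1 to compound 2 (0.02 log units; within the scatter) shows that the two are indistinguishable within the scatter. The next compound, compound 3 `Fc1ccc(NC(=S)Nc2cccc(C(F)(F)F)c2)cc1`, has not yet been measured in this assay.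

Compound 3 differs from compound 2 in one place: fluoro in place of 4-butylcyclohexyl on an aromatic carbon.

For the measured compounds named here, the single measured step, from compound 1 to compound 2, concerns only the length of the chain on the saturated ring and was within the scatter. Going by the values given here, no measured step touches the removal of the whole 4-butylcyclohexyl group or the entry of fluoro, so there is no direct precedent for this change. The expectation for compound 3 therefore rests on the level of the two measured compounds, with a wide range. The step of a 1.6-fold higher number from compound 2 to compound 3 (0.20 log units; within the scatter) is the expected outcome. Compound 3 is estimated at 15000 nM, with a range from 5000 nM to 45000 nM.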

Compound 3, half-maximal cytotoxic concentration: 26000 nM
For compound 3 the middle estimate is 1.7-fold (0.24 log units) below the measured one, and the stated range covers the measured number.
By their numbers in this assay, from the lowest: compounds 2 and 1 (each within the scatter of the next); then compound 3.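

For the compounds shown here, exchanging the whole group on this aromatic carbon is the first change to move the number in this assay beyond the scatter, in the direction of more compound tolerated (a 2.7-fold higher number from compound 2 to compound 3 (0.44 log units; beyond the scatter)), and the step is modest. The same exchange starting from 4-ethylcyclohexyl gives a matching result (a 2.6-fold higher number from compound 1 to compound 3 (0.41 log units; beyond the scatter)), so the outcome does not hang on which of the two chain lengths leaves, and replacing an all-carbon group holding a ring and two defined stereocentres with a single fluorine atom matters more here than the chain change on the saturated ring, which stayed within the scatter. Nothing measured on these compounds explains the step.

The compounds shown leave open whether the rise goes with the loss of 4-butylcyclohexyl or with the entry of fluoro; hydrogen, chloro or an unsubstituted cyclohexyl on this aromatic carbon would separate the two. Also open, as far as these compounds go, is where a small group such as methyl or methoxy would fall, and whether the step holds when the trifluoromethyl group of the shared core is replaced by a nitrile.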